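Methoxy added to a thiol-bearing compound at the limit

This account rests on a few compounds, and the source may have more. Where it says the series, first, only, none or still open, it means among the compounds named here.

Measured compounds:
Compound 1 `COc1ccc(CNc2nc([Se]C)nc3ccccc23)cc1` — > 100000 nM
Compound 2 `Sc1nc(NCc2ccccc2)c2ccccc2n1` — > 100000 nM

In a functional assay on CCRF-CEM cells (Homo sapiens) for cytotoxicity, read by MTT assay, with a stated time of 72 h (a higher number here means that more compound is tolerated, a lower number that less compound is tolerated), compound 1 gives > 100000 nM, which is a limit of the assay and not a number. In this assay compound 2 gives > 100000 nM, again a limit rather than a number. Compound 2 therefore stands nowhere above or below the other value shown: both values sit at the same point, as summed up by the limit of > 100000 nM in this assay, at which 2 of the 2 values shown sit. Within the data shown here, no step between two measured compounds can be drawn from these data, so no measured change in this assay is known.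

Compound 3 `COc1ccc(CNc2nc(S)nc3ccccc23)cc1` is not yet measured. It differs from compound 2 by methoxy in place of hydrogen on an aromatic carbon. Compound 1 already carries this methoxy group on the same position and sits at the limit, and compound 2 without it sits at the limit as well. Given that compound 1 gives > 100000 nM, the step from compound 2 to compound 3 is expected to be a step that the limit leaves unreadable from compound 2 to compound 3, that is, none beyond the scatter. Compound 3 is therefore estimated at 150000 nM in this assay, within 50000 nM to 500000 nM, and most likely reported only as a limit.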

Compound 3, concentration lethal to 50% of the cells: 71600 nM
The estimate for compound 3 lay 2.1-fold (0.32 log units) above the measured number; low and high end bracket the measured number.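

In this assay compound 3 is the only one of the three compounds shown that gives a number rather than a limit, so a thiol-bearing compound with methoxy on an aromatic carbon, para to a large group, does fall within the range that this assay can read. Methoxy in place of hydrogen gives an at least 1.3-fold lower number from compound 2 to compound 3 (0.14 log units; that floor lies within the scatter), and one sulfur atom in place of the group holding carbon and selenium gives an at least 1.3-fold lower number from compound 1 to compound 3 (0.14 log units; that floor lies within the scatter). Each of these steps is only a floor, and neither shows a change beyond the scatter, because the other end of each step is a limit: the limit of > 100000 nM in this assay, at which 2 of the 3 values shown sit.

The compounds shown leave open how far compound 1 and compound 2 lie past that limit, and so what the true size of either step is. They also leave open whether an amine, a carboxylic acid or a longer chain in place of methoxy at this position would give a number in this assay, and whether methoxy would give one with a methylseleno group kept on the core.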